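The source may hold more compounds than are shown below. What is called first, only, known or untested is meant among the compounds shown, and "the series" means these compounds.

Measured in an in vitro ADME assay on microsomes from liver (Rattus norvegicus) for metabolic stability; a lower number here means slower removal, a higher number faster removal of the compound:
Compound 1 `COC(=O)[C@H]1CC[C@@H](n2/c(=N/C(=O)c3ccccc3)[nH]c3ccc(CN4CCCCC4)cc32)CC1`: 459 mL.min-1.g-1
Compound 2 `CC(C)NC(=O)[C@H]1CC[C@@H](n2/c(=N/C(=O)c3ccc(F)c(F)c3)[nH]c3ccc(CN4CCC(C(C)(C)O)CC4)cc32)CC1`: 19 mL.min-1.g-1

Compound 2 holds the lower of the two numbers, and the gap to compound 1 at 459 mL.min-1.g-1 lies beyond the scatter. These two compounds differ in more than one place, so their gap gives no reading on any single change.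

Compound 3 `CC(C)NC(=O)[C@H]1CC[C@@H](n2/c(=N/C(=O)c3ccccc3)[nH]c3ccc(CN4CCC(C(C)(C)O)CC4)cc32)CC1` carries phenyl in place of 3,4-difluorophenyl on a carbonyl carbon. Among the compounds with values here, no measured pair isolates this change, so the expectation is only a small upward move in this assay, not beyond the scatter: a 1.3-fold higher number from compound 2 to compound 3 (0.12 log units; within the scatter). For compound 3 the estimated value is 25 mL.min-1.g-1, with an expected range of 11 mL.min-1.g-1 to 55 mL.min-1.g-1.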

Compound 3, intrinsic clearance in microsomes: 21 mL.min-1.g-1
Estimate against measurement, compound 3: 1.2-fold (0.08 log units) above, within the range that was stated.
By their numbers in this assay, from the lowest: compounds 2 and 3 (each within the scatter of the next); then compound 1.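

In this assay, within the data shown here, phenyl in place of 3,4-difluorophenyl on a carbonyl carbon gives a 1.1-fold higher number from compound 2 to compound 3 (0.04 log units; within the scatter), the first reading of a single change. With the rest of compound 2 held constant, the low number therefore does not depend on the two fluorine atoms at this position. Nothing at hand gives a cause for this reading.

Still open, from the compounds shown here alone, is whether a cyclohexyl group on the same carbonyl carbon, or a phenyl carrying a nitrile or methoxy group, would stay within the scatter of compound 3.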